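Bromo in Place of Dimethylamino

The compounds below may be only part of what the source reports. "The series", "measured", "known", "first", "only" and "open" are said of these compounds alone.

In a functional assay on ECa-109 cells (Homo sapiens) for cytotoxicity, read by MTT assay, with a stated time of 72 h (a higher number here means a weaker inhibitor, a lower number a stronger inhibitor), compound 1 `CCC(C)=C1C(=O)N(c2ccc(Cl)cc2)N(c2ccc(Cl)cc2)C1=O` gives 41100 nM. Compound 2 `CN(C)c1ccc(C=C2C(=O)N(c3ccc(Cl)cc3)N(c3ccc(Cl)cc3)C2=O)cc1` gives only a limit in this assay, > 128000 nM. This places compound 2 at the limit of > 128000 nM in this assay, at which 1 of the 2 values shown sits, which is all that can be said of where it stands. Compound 3 `O=C1C(=Cc2ccc(Br)cc2)C(=O)N(c2ccc(Cl)cc2)N1c1ccc(Cl)cc1` has not yet been measured; it differs from compound 2 by bromo in place of dimethylamino on an aromatic carbon. Going by the values given here, because compound 2 sits at the limit of > 128000 nM in this assay, at which 1 of the 2 values shown sits, no measured step sets the size of this change, and a step of an at least 1.8-fold lower number from compound 2 to compound 3 (0.26 log units; that floor lies within the scatter) toward a stronger inhibitor is expected, possibly no larger than the usual scatter. Compound 3 is estimated at 70000 nM, between 20000 nM and 200000 nM.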

Compound 3, half-maximal inhibitory concentration: 12300 nM
Compound 3: middle estimate off by 5.7-fold (0.76 log units), on the high side, outside the stated range (below it).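

Replacing 4-(dimethylamino)phenyl with 4-bromophenyl gives an at least 10-fold lower number from compound 2 to compound 3 (1.01 log units; beyond the scatter), so the group at this aromatic carbon clearly matters in this assay. Going by these compounds alone, this is the first measured step at this position, and it shows that a single change of group here can move the result well beyond the scatter. The printed size is only a floor, and the true step could be larger: the limit of > 128000 nM in this assay, at which 1 of the 3 values shown sits.

The compounds shown do not settle whether the result is specific to bromo. Chloro, methoxy or plain hydrogen at the same carbon could give a similar number or a very different one.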